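This account rests on a few compounds, and the source may have more. Where it says the series, first, only, none or still open, it means among the compounds named here.

Measured in an ADME assay on microsomes from liver (Mus musculus, strain CD-1) for metabolic stability, read by LC-MS, with a stated time of 60 min, tested at 20 uM; a lower number here means that the compound disappears faster, a higher number that the compound lasts longer:
- compound 1 `CC(Sc1nc2c(cnn2C)c(=O)n1-c1ccccc1)c1ccccn1`: 0.833 h
- compound 2 `CC(Sc1nc2c(cnn2C)c(=O)n1-c1ccccc1)c1cccnc1`: 0.117 h

Compound 2 stands lower of the two. Next comes compound 3 `CC(Sc1nc2c(cnn2C)c(=O)n1-c1ccccc1)c1cccc(O)c1`, with 3-hydroxyphenyl in place of pyridin-3-yl on a saturated chain carbon bound to a saturated chain carbon and a sulfur. Going by the values given here, one measured step bears on this change, a swap at the same place: a 7.1-fold lower number from compound 1 to compound 2 (0.85 log units; beyond the scatter). That modest step shows that a swap here can move the number beyond the scatter, but it gives no direction for the new group. The expected step is small and upward, probably within the scatter: a 1.7-fold higher number from compound 2 to compound 3 (0.23 log units; within the scatter). For compound 3 the estimated value is 0.2 h, with an expected range of 0.06 h to 0.6 h.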

Compound 3, half-life: 0.0667 h
Beside the measured number, compound 3's estimate is 3.0-fold (0.48 log units) above it, within the range that was stated.
By their numbers in this assay, from the lowest: compounds 3 and 2 (each within the scatter of the next); then compound 1.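

In this assay, 3-hydroxyphenyl and pyridin-3-yl on this saturated chain carbon cannot be told apart, with a 1.8-fold lower number from compound 2 to compound 3 (0.24 log units; within the scatter) as the step between them. Against pyridin-2-yl, the 3-hydroxyphenyl swap gives a 12-fold lower number from compound 1 to compound 3 (1.10 log units; beyond the scatter), so among these three groups only pyridin-2-yl separates from the others. Nothing on hand accounts for that separation.

As far as these compounds go, whether an amine or a carboxylic acid at this carbon would come nearer to compound 1 stays open. So does whether a 2-hydroxyphenyl would follow pyridin-2-yl or 3-hydroxyphenyl.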